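Swapping a para acetyl for a hydroxy on a shared core

This account rests on a few compounds, and the source may have more. Where it says the series, first, only, none or still open, it means among the compounds named here.

Measured so far:
compound 1, `COc1cc(-n2cnc3ccc(-c4ccc(C(C)=O)cc4)cc32)cc(OC)c1OC`, 2510 nM in a functional assay on A549 cells (Homo sapiens) for antiproliferative activity, read by MTT assay, with a stated time of 72 h; on this read-out higher numbers stand for weaker inhibition and lower numbers for stronger inhibition
compound 2, `COc1ccc(-c2ccc3ncn(-c4cc(OC)c(OC)c(OC)c4)c3c2)cc1F`, 1430 nM
compound 3, `COc1cc(-n2cnc3ccc(-c4cc(F)ccc4F)cc32)cc(OC)c1OC`, 7940 nM

Compound 1 stands second highest of these three. Its nearest neighbour is compound 2, reached by a 1.8-fold lower number from compound 1 to compound 2 (0.24 log units; within the scatter), and its furthest is compound 3, reached by a 3.2-fold higher number from compound 1 to compound 3 (0.50 log units; beyond the scatter). Compound 4, `COc1cc(-n2cnc3ccc(-c4ccc(O)cc4)cc32)cc(OC)c1OC`, differs from compound 1 by hydroxy in place of acetyl on an aromatic carbon. For the measured compounds named here, no measured step exchanges the acetyl directly; the step to compound 2 shows that changing this ring's substituents stays within the scatter, while the step to compound 3 shows a modest loss. A step of about a 1.0-fold lower number from compound 1 to compound 4 (0.00 log units; within the scatter) is expected, within the scatter. Compound 4 is estimated at 2500 nM, between 900 nM and 7000 nM.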

Compound 4, half-maximal inhibitory concentration: 5090 nM
Compound 4: middle estimate off by 2.0-fold (0.31 log units), on the low side, and the stated range covers the measured number.
By their numbers in this assay, from the lowest: compounds 2 and 1 (each within the scatter of the next); then compounds 4 and 3 (each within the scatter of the next).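

In this assay, exchanging acetyl directly for hydroxy gives a 2.0-fold higher number from compound 1 to compound 4 (0.31 log units; beyond the scatter), so this single group change at the position costs a modest amount of inhibition. Measured against the 3-fluoro-4-methoxyphenyl group, the 4-hydroxyphenyl group gives a 3.6-fold higher number from compound 2 to compound 4 (0.55 log units; beyond the scatter), whereas against the 2,5-difluorophenyl group it gives a 1.6-fold lower number from compound 3 to compound 4 (0.19 log units; within the scatter), which leaves those two groups indistinguishable. Nothing available accounts for these steps. As far as these compounds go, whether an amine or a carboxylic acid at this position would sit closer to compound 1 or to compound 4 stays open.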